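The source may hold more compounds than are shown below. What is called first, only, known or untested is meant among the compounds shown, and "the series" means these compounds.

Three compounds have been measured in an ADME assay on L6 cells (Rattus norvegicus) for cytotoxicity, read by resazurin assay, with a stated time of 72 h; a higher number here means a weaker inhibitor, a lower number a stronger inhibitor:

Compound 1 `CC(C)Oc1cccc(C(O)(c2ccc(Cl)cc2)c2cccnc2)c1` gives 67600 nM.
Compound 2 `CC(C)Oc1ccc(C(O)(c2ccc(Cl)cc2)c2cccnc2)cc1` gives 56600 nM.
Compound 3 `N#Cc1cccc(C(O)(c2ccc(Cl)cc2)c2cccnc2)c1` gives only a limit of the assay, > 100000 nM.

Compound 1 and compound 2 are built from the same atoms joined differently; the difference between the two cores is not broken down here. Their two values lie within the usual scatter of each other, so no order can be read between them.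

Compound 3 arises from compound 1 by the change (cyano in place of isopropoxy on an aromatic carbon). This change brings an at least 1.4-fold higher number from compound 1 to compound 3 (0.17 log units; that floor lies within the scatter), and that step is only a floor because of the limit of > 100000 nM in this assay, at which 1 of the 3 values shown sits.

Compound 4 `N#Cc1ccc(C(O)(c2ccc(Cl)cc2)c2cccnc2)cc1` has not yet been measured. It arises from compound 2 by cyano in place of isopropoxy on an aromatic carbon. This is the same kind of change as from compound 1 to compound 3, but the surroundings of the place differ: in the measured pair the new group sits meta to a large group, whereas in compound 4 it sits para to a large group.

Going by the values given here, the expectation for compound 4 rests on the one measured step of an at least 1.4-fold higher number from compound 1 to compound 3 (0.17 log units; that floor lies within the scatter) and on compound 2 standing at 56600 nM, so a step of comparable size is expected. For compound 4 the expected value is 90000 nM. For compound 4 the expected lower end is 45000 nM and the expected upper end 200000 nM. The expected step is a 1.6-fold higher number from compound 2 to compound 4 (0.20 log units; within the scatter).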

Compound 4, half-maximal inhibitory concentration: > 100000 nM
Compound 4 gave a limit, no number (the forecaster's own chance of this, stated with the estimate: 40%); at least 1.1-fold (0.04 log units) between middle value and limit.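

Carried to the core of compound 2, cyano in place of isopropoxy on an aromatic carbon gives in this assay an at least 1.7-fold higher number from compound 2 to compound 4 (0.24 log units; that floor lies within the scatter), and that step, like the earlier one, is only a floor. Compound 4 gives > 100000 nM, which is a limit of the assay and not a number: the limit of > 100000 nM in this assay, at which 2 of the 4 values shown sit. Set side by side, the two steps show that the change leaves both cores without a measured number and that neither floor reaches beyond the scatter, but they do not show that the change has a real effect on either core, nor that its size carries over from one core to the other: the same change on two cores in this assay, an at least 1.4-fold higher number (0.17 log units; that floor lies within the scatter) from compound 1 to compound 3 and an at least 1.7-fold higher number (0.24 log units; that floor lies within the scatter) from compound 2 to compound 4; the limit leaves it open whether they differ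

The compounds shown hold only isopropoxy and cyano at this place, so it stays open how an amine, a carboxylic acid or a longer chain on the same aromatic carbon would read in this assay. Also open, as far as these compounds go, are the actual values of compound 3 and compound 4, and with them whether the step differs between the two cores at all.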